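The source may hold more compounds than are shown below. What is called first, only, known or untested is meant among the compounds shown, and "the series" means these compounds.

In a functional assay on HeLa cells (Homo sapiens) for inhibition (a higher number here means a weaker inhibitor, a lower number a stronger inhibitor), compound 2 `COc1c([N+](=O)[O-])cc(/C=C/c2ccc3ccccc3c2)cc1[N+](=O)[O-]` gives > 5000 nM as a limit of the assay, not a number. Compound 3 `COc1c([N+](=O)[O-])cc(/C=C\c2ccc3ccccc3c2)cc1[N+](=O)[O-]` differs from it in one way: the two compounds have the same atoms and bonds and differ only in configuration as drawn: 1 of 1 stereo elements differ; a double bond is drawn E in compound 2 and Z in compound 3 with a double bond drawn E in compound 2 and Z in compound 3. Compound 1 `COc1cc(/C=C\c2ccc3ccccc3c2)cc([N+](=O)[O-])c1OC`, whose double bond is also drawn Z, gives 110 nM and this makes stronger inhibition the expectation for compound 3. The expected change, an at least 12-fold lower number from compound 2 to compound 3 (1.09 log units; beyond the scatter), is a large one, well beyond the scatter. Compound 3 is estimated at 400 nM with an expected range from 60 nM to 3000 nM around that figure.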

Compound 3, half-maximal inhibitory concentration: > 5000 nM
Compound 3 was reported as a limit (the forecaster's own chance of this, stated with the estimate: 20%); at least 12-fold (1.09 log units) between middle value and limit.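

In this assay, nitro in place of methoxy on an aromatic carbon gives an at least 45-fold higher number from compound 1 to compound 3 (1.65 log units; beyond the scatter), so this position matters and a double bond drawn Z does not secure strong inhibition by itself. The step between compound 2 and compound 3 cannot be read, because both values are limits of the assay, and so this result says nothing about the effect of the double bond's configuration here: the limit of > 5000 nM in this assay, at which 2 of the 3 values shown sit.

From the compounds shown here alone, whether configuration matters at all once nitro replaces methoxy stays open: the fact that compounds 2 and 3 differ only in the configuration as drawn Also open is how an amine or a carboxylic acid at this position would compare with methoxy.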